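The source may report more compounds than this note shows. Statements on the series, on what has been measured and on what is new or still open speak of the compounds shown alone.

Working notes on the series. The compounds share one core: compound 1 `COC(=O)/C=C/c1cccc(N(Cc2ccc(-c3ccc(F)c(Cl)c3)cc2)C(=O)C2CCCCC2)c1`, compound 2 `COC(=O)/C=C/c1cccc(N(Cc2ccc(C(C)(C)C)cc2)C(=O)C2CCCCC2)c1` and compound 3 `COC(=O)/C=C/c1cccc(N(Cc2ccc(/C=C/C(=O)NC(C)(C)C)cc2)C(=O)C2CCCCC2)c1` differ only in the group on the aromatic carbon of the benzyl arm. In an assay on isolated protein with Bile acid receptor (Homo sapiens) as the target (a higher number here means that more compound is needed for the effect, a lower number that less compound is needed), compound 1 gives 66 nM. For compound 2 the assay reports only a limit, > 1000 nM. For compound 3 the assay likewise reports only a limit, > 1000 nM. Compound 3 thus has no number of its own; it sits at the limit of > 1000 nM in this assay, at which 2 of the 3 values shown sit, where compound 2 also stands. Among the measured compounds shown here, the two measured steps from the one numeric value are an at least 15-fold higher number from compound 1 to compound 2 (1.18 log units; beyond the scatter) and an at least 15-fold higher number from compound 1 to compound 3 (1.18 log units; beyond the scatter). Between the two limits the step is a step that the two limits leave unreadable from compound 2 to compound 3.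

Compound 4 `COC(=O)/C=C/c1cccc(N(Cc2ccc(/C=C/c3ccc(F)cc3)cc2)C(=O)C2CCCCC2)c1` is not yet measured. Against compound 3 the change is 4-fluorophenyl in place of (tert-butyl)carbamoyl on a double-bonded chain carbon bound to a double-bonded chain carbon. For the measured compounds named here, no measured step covers this exchange directly; what the measured steps show is that 3-chloro-4-fluorophenyl on the aromatic carbon gave a number, while tert-butyl and 2-((tert-butyl)carbamoyl)ethenyl both ended at the limit. Compound 4 carries a 4-fluorophenyl on the ethenyl chain, so a value below the limit is expected, read as an at least 3.3-fold lower number from compound 3 to compound 4 (0.52 log units; beyond the scatter). Compound 4 is estimated at 300 nM, with a range from 60 nM to 1500 nM.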

Compound 4, half-maximal effective concentration: 185 nM
Compound 4: the middle estimate sits 1.6-fold (0.21 log units) above what was measured; the range from low to high includes it.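

In this assay, 4-fluorophenyl in place of (tert-butyl)carbamoyl on a double-bonded chain carbon bound to a double-bonded chain carbon gives an at least 5.4-fold lower number from compound 3 to compound 4 (0.73 log units; beyond the scatter) and brings the series back to a measurable number, so the ethenyl chain alone does not hold a compound at the limit; the comparison with the smaller tert-butyl group gives an at least 5.4-fold lower number from compound 2 to compound 4 (0.73 log units; beyond the scatter) as well. Measurable binding is therefore not confined to the directly attached 3-chloro-4-fluorophenyl, although the change to 2-(4-fluorophenyl)ethenyl still costs something, with a 2.8-fold higher number from compound 1 to compound 4 (0.45 log units; beyond the scatter) and the ethenyl chain and the chlorine changing together in that step. The first two steps are bounds rather than sizes, as compounds 2 and 3 each have only a limit and no number: the limit of > 1000 nM in this assay, at which 2 of the 4 values shown sit.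

Open, as far as these compounds go, is whether the aromatic ring alone carries the gain over (tert-butyl)carbamoyl or whether its fluorine contributes, which an unsubstituted phenyl on the same chain would separate. Also open, from the compounds shown here alone, is how 2-(3-chloro-4-fluorophenyl)ethenyl would compare, and whether a pyridyl ring or a carboxylic acid is accepted on the double-bonded chain carbon.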